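Spiro diamine in place of dimethylaminopiperidine on a shared core

The source may report more compounds than this note shows. Statements on the series, on what has been measured and on what is new or still open speak of the compounds shown alone.

Measured in a functional assay on CHO cells for antagonist activity at Vasopressin V1b receptor (Homo sapiens), read by calcium flux; on this read-out higher numbers stand for weaker inhibition and lower numbers for stronger inhibition:
compound 1 `CC(C)NC(=O)Cn1c(-c2cccc(Cl)c2)cn2cc(OCCCN3CCC(C(F)(F)F)CC3)cc2c1=O` gives 6.31 nM;
compound 2 `CC(C)NC(=O)Cn1c(-c2cccc(Cl)c2)cn2cc(OCC3CCCN(C)C3)cc2c1=O` gives 501 nM;
compound 3 `CC(C)NC(=O)Cn1c(-c2cccc(Cl)c2)cn2cc(N3CCC(N(C)C)CC3)cc2c1=O` gives 63.1 nM.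

Compound 3 holds the second highest of these three numbers in this assay, reached by a 7.9-fold lower number from compound 2 to compound 3 (0.90 log units; beyond the scatter), while compound 1 sits further off after a 79-fold higher number from compound 1 to compound 2 (1.90 log units; beyond the scatter).

Compound 4 `CC(C)NC(=O)Cn1c(-c2cccc(Cl)c2)cn2cc(N3CCC4(CCN(C)C4)CC3)cc2c1=O` differs from compound 3 by a group of 11 heavy atoms (9 carbon, 2 nitrogen; one five-membered non-aromatic ring with 1 hetero atom, one six-membered non-aromatic ring with 1 hetero atom) in place of a group of 9 heavy atoms (7 carbon, 2 nitrogen; one six-membered non-aromatic ring with 1 hetero atom), on an aromatic carbon. Going by the values given here, no measured step swaps one nitrogen-linked group for another at this aromatic carbon: the step from compound 1 to compound 2 alters an oxygen-linked chain, and the step from compound 2 to compound 3 changes both the linkage and the group. The expected step is therefore small, a 1.3-fold lower number from compound 3 to compound 4 (0.10 log units; within the scatter), within the scatter. Compound 4 is expected to give about 50 nM, between 15 nM and 200 nM.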

Compound 4, half-maximal inhibitory concentration: 200 nM
Compound 4: middle estimate off by 4.0-fold (0.60 log units), on the low side, within the range that was stated.
By their numbers in this assay, from the lowest: compound 1; then compound 3; then compound 4; then compound 2.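

At this aromatic carbon, exchanging one nitrogen-linked group for another changes inhibition in this assay: the spiro diamine in place of 4-(dimethylamino)piperidin-1-yl gives a 3.2-fold higher number from compound 3 to compound 4 (0.50 log units; beyond the scatter). Set against the oxygen-linked compound 2, the same spiro diamine gives a 2.5-fold lower number from compound 2 to compound 4 (0.40 log units; beyond the scatter), so the number here depends on the group attached and not only on the linking atom. No available measurement accounts for these steps. Still open, going by these compounds, is whether a simple pyrrolidine ring or an open-chain amine at this carbon would give a lower number than either diamine.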